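The compounds below may be only part of what the source reports. "The series", "measured", "known", "first", "only" and "open" are said of these compounds alone.

In an ADME assay on CCRF-HSB-2 cells (Homo sapiens) for cytotoxicity, with a stated time of 7 days (a higher number here means that more compound is tolerated, a lower number that less compound is tolerated), compound 1 (`CC(C)CSc1nc(N)nc2c1ncn2/C=C1/CC1(CO)CO`) gives 60000 nM as a real number. For compound 2 (`COCCOc1nc(N)nc2c1ncn2/C=C1/CC1(CO)CO`) the reading > 20000 nM is a limit. For compound 3 (`CC(C)Nc1nc(N)nc2c1ncn2/C=C1/CC1(CO)CO`) the reading > 20000 nM is also a limit, so compound 3 stands at the limit of > 20000 nM in this assay, at which 2 of the 3 values shown sit, and has no exact number. Compound 4 (`Nc1nc(NC2CC2)c2ncn(/C=C3/CC3(CO)CO)c2n1`) differs from compound 3 by one change (cyclopropyl in place of isopropyl on a nitrogen on an aromatic ring): cyclopropyl in place of isopropyl on a nitrogen on an aromatic ring. The measured steps that touch this group, a step that the limit leaves unreadable from compound 1 to compound 3 and a step that the two limits leave unreadable from compound 2 to compound 3, give no readable size. No shift beyond the usual scatter, in either direction, is therefore expected, and the expected step is a step that the limit leaves unreadable from compound 3 to compound 4 in this comparison. Compound 4 is estimated at 30000 nM with 10000 nM to 100000 nM as the expected range.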

Compound 4, half-maximal cytotoxic concentration: > 20000 nM
Compound 4: a limit, no number; the forecaster's own chance of this, stated with the estimate: 65%; the middle value is on the limit's open side.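

Compound 4 gives a limit rather than a number, so its steps from compound 1, compound 2 and compound 3 cannot be read: the limit of > 20000 nM in this assay, at which 3 of the 4 values shown sit.

The compounds shown leave open how compound 2, compound 3 and compound 4 compare with one another and with compound 1.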